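Chloro for hydrogen on the thiazole-bound phenyl

This account rests on a few compounds, and the source may have more. Where it says the series, first, only, none or still open, it means among the compounds named here.

Measured compounds and their readings:
compound 1 `Cc1nc(-c2ccc(Cl)cc2)sc1C(=O)CSc1nc(-c2ccc(Cl)c(Cl)c2)c(C#N)c(=O)[nH]1` — 93.9%
compound 2 `COc1ccc(-c2nc(SCC(=O)c3sc(-c4ccc(Cl)cc4)nc3C)[nH]c(=O)c2C#N)cc1OC` — 59.8%
compound 3 `COc1cccc(-c2nc(SCC(=O)c3sc(-c4ccccc4)nc3C)[nH]c(=O)c2C#N)c1` — 80.3%

All three were read in a functional assay on U-87MG ATCC cells for antiproliferative activity against U-87 MG (Homo sapiens), read by MTT assay, with a stated time of 48 h, tested at 50 uM; a higher number here means a weaker effect of the compound at the concentration tested, a lower number a stronger effect. Compound 3 stands second highest of the three numbers: compound 1 sits higher, beyond the scatter, and compound 2 sits lower, also beyond the scatter. Going by the values given here, the only single-point step among the measured compounds is a number 34.1 percentage points lower from compound 1 to compound 2 (beyond the scatter), a large drop that goes with 3,4-dimethoxyphenyl in place of 3,4-dichlorophenyl on an aromatic carbon. That step changes the aryl on the pyrimidinone side and does not touch the place that matters here.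

Compound 4 `COc1cccc(-c2nc(SCC(=O)c3sc(-c4ccc(Cl)cc4)nc3C)[nH]c(=O)c2C#N)c1` differs from compound 3 by chloro in place of hydrogen on an aromatic carbon, on the phenyl attached to the thiazole side of the shared core. Among the compounds with values here, compounds 1 and 2 already carry the chloro at this place, compound 3 does not, but no pair among them isolates this change alone, so no measured step bears on it directly. The expectation is therefore a step of a number 0.3 percentage points lower from compound 3 to compound 4 (within the scatter), none beyond the scatter, with the estimate for compound 4 in this assay set at 80%, expected to lie between 65% and 95%.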

Compound 4, a percentage reported as activity, at one concentration (the size of the read-out at that concentration, not a potency): 47.6%
The estimate for compound 4 lay 32.4 percentage points above the measured number, outside the stated range (below it).
By their numbers in this assay, from the lowest: compound 4; then compound 2; then compound 3; then compound 1.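

In this assay, going by these compounds alone, the change from phenyl to 4-chlorophenyl, one chloro on an aromatic carbon para to a large group, gives a number 32.7 percentage points lower from compound 3 to compound 4 (beyond the scatter) and is the first isolated reading at this position, which proves far from silent. Compound 4 also gives the lowest number of the four, since the aryl on the other side still matters with this chloro in place: a number 12.2 percentage points lower from compound 2 to compound 4 (beyond the scatter) goes with hydrogen in place of methoxy, and a number 46.3 percentage points lower from compound 1 to compound 4 (beyond the scatter) goes with 3-methoxyphenyl in place of 3,4-dichlorophenyl. Nothing available accounts for the size of the chloro step or for these differences on the other aryl.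

As far as these compounds go, the chloro step is read against a single partner, 3-methoxyphenyl, so its size with 3,4-dimethoxyphenyl or 3,4-dichlorophenyl on the other side remains open. Also open, from the compounds shown here alone, is whether fluoro, methyl, methoxy or an amine at the same aromatic carbon would follow chloro, and whether the reading at this one concentration would carry over to a potency.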